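The compounds below may be only part of what the source reports. "The series", "measured", "known", "first", "only" and "open" are said of these compounds alone.

In a functional assay on Huh-7 cells (Homo sapiens) for cytotoxicity, with a stated time of 48 h (on this read-out lower numbers stand for stronger inhibition and higher numbers for weaker inhibition), compound 1 `COc1cc(OC)c(C(=O)/C=C/c2ccccc2OC)c(OC)c1` gives 9800 nM while compound 2 `COc1cc(OC)c(C(=O)/C=C/c2ccc(Cl)cc2)c(OC)c1` gives 12700 nM on the same scale. Among the compounds with values here, compound 2 therefore has compound 1 as its only neighbour, and the two stand level within the usual scatter. The next structure is compound 3 `COc1cc(OC)c(C(=O)/C=C/c2ccc(F)cc2)c(OC)c1`, which has fluoro in place of chloro on an aromatic carbon, para to a large group. Within the data shown here, no measured pair tests this swap directly. Among the measured compounds shown here, the one measured step that bears on it is the replacement of 2-methoxyphenyl by 4-chlorophenyl (a 1.3-fold higher number from compound 1 to compound 2 (0.11 log units; within the scatter)), which stays within the scatter while exchanging a whole substituted phenyl group. A swap of a single atom is therefore expected to give no step beyond the scatter in this assay as well. The expected step is small (a 1.1-fold lower number from compound 2 to compound 3 (0.04 log units; within the scatter)). For compound 3 the estimated value is about (11500 nM), with an expected range from (5500 nM) to (24000 nM).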

Compound 3, half-maximal inhibitory concentration: 14600 nM
Compound 3: middle estimate off by 1.3-fold (0.10 log units), on the low side, and the stated range covers the measured number.
By their numbers in this assay, from the lowest: compounds 1, 2 and 3 (each within the scatter of the next).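

In this assay, within the data shown here, fluoro in place of chloro on the aromatic carbon para to a large group gives a 1.1-fold higher number from compound 2 to compound 3 (0.06 log units; within the scatter) and is the first direct test of a single-atom swap at this place, with no change that can be told from the scatter. The wider exchange of 2-methoxyphenyl for 4-fluorophenyl gives a 1.5-fold higher number from compound 1 to compound 3 (0.17 log units; within the scatter) and also stays within the scatter, so the three compounds stand level on this read-out. No measurement at hand offers an explanation for this flat picture.

Among these compounds, every step so far stays within the scatter, so it remains open whether any group at this place can move the number clearly in either direction. An amine or a carboxylic acid on that aromatic carbon would test this with a group of a very different kind from chloro and fluoro.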